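The source may hold more compounds than are shown below. What is called first, only, known or untested is meant among the compounds shown, and "the series" means these compounds.

Working notes on the series, read out in a functional assay on Raji cells (Homo sapiens) for cytotoxicity, with a stated time of 72 h; a higher number here means that more compound is needed for the effect, a lower number that less compound is needed. Compound 1 (`C=C[C@@](C)(/C=C/c1ccc(O)cc1)CCC(O)C(C)(C)O`) gives > 26000 nM, a limit and not a number. Compound 2 (`C=C[C@@](C)(/C=C/c1ccc(O)c(/C=C/C(=O)OCC)c1)CCC=C(C)C`) gives > 26000 nM, again a limit. Compound 3 (`CCOC(=O)/C=C/c1cc(/C=C/[C@](C)(/C=C/c2ccc(OC)cc2)CCC=C(C)C)ccc1O`) gives > 26000 nM, also only a limit, so it has no number to rank against the other two.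

Compound 4 (`COc1ccc(/C=C/[C@@](C)(/C=C/c2ccc(O)c(/C=C/C(=O)c3ccccc3)c2)CCC=C(C)C)cc1`) is not yet measured. It differs from compound 3 as follows: phenyl in place of ethoxy on a carbonyl carbon. Put another way, the 2-(ethoxycarbonyl)ethenyl of compound 3 becomes 2-benzoylethenyl in compound 4.

Among the compounds with values here, the only measured step, a step that the two limits leave unreadable from compound 2 to compound 3, lies at another place and has no readable size. Within the data shown here, no measured step tests this change. What remains is the limit of > 26000 nM in this assay, at which 3 of the 3 values shown sit. On that basis, at most a modest move toward lower numbers is expected, and a further limit is the likeliest single outcome. The expected step is an at least 1.4-fold lower number from compound 3 to compound 4 (0.15 log units; that floor lies within the scatter). For compound 4 the estimated value is 18000 nM, with an expected range from 5000 nM to 40000 nM.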

Compound 4, half-maximal effective concentration: > 26000 nM
Compound 4: a limit, no number; the forecaster's own chance of this, stated with the estimate: 55%; at least 1.4-fold (0.15 log units) between middle value and limit.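

Compound 3 and compound 4 both stand at limits in this assay, and the step between them cannot be read. The compounds shown leave open what phenyl in place of ethoxy does to the number, and which structure in the series would give a number at all: the limit of > 26000 nM in this assay, at which 4 of the 4 values shown sit.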